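From 2-fluorophenyl to 4-bromophenyl on a shared core

A few compounds are considered here, and "the series" means these few. Any claim that something is new, unique, unknown or untested is made for them only; others in the source may bear on it.

Measured so far:
Compound 1 `COc1cc(OC)c(-c2coc3cc(OCC=C(C)C)ccc3c2=O)cc1OC`: 3800 nM
Compound 2 `COc1cc(OC)c(-c2coc3cc(OCc4ccccc4F)ccc3c2=O)cc1OC`: 4300 nM

Both values come from a functional assay on HUVEC cells (Homo sapiens) for antiproliferative activity, read by MTT assay, with a stated time of 24 h; a lower number here means a stronger inhibitor, a higher number a weaker inhibitor. Among the compounds with values here, compound 2 stands level with compound 1, the only other compound measured, so neither ranks ahead of the other. The next compound is compound 3 `COc1cc(OC)c(-c2coc3cc(OCc4ccc(Br)cc4)ccc3c2=O)cc1OC`, which keeps the shared core but carries 4-bromophenyl in place of 2-fluorophenyl on a saturated chain carbon bound to an oxygen on an aromatic ring. Within the data shown here, only one measured step bears on this change. It put 2-fluorophenyl in place of 2-methylprop-1-en-1-yl on that same carbon, and it was a 1.1-fold higher number from compound 1 to compound 2 (0.05 log units; within the scatter). Among the measured compounds shown here, with only that small step from compound 2's side to go on, no change beyond the scatter is expected in this assay, although one step is thin evidence. The expected step is a 1.1-fold lower number from compound 2 to compound 3 (0.03 log units; within the scatter). For compound 3 the estimated value is 4000 nM, with an expected range from 1800 nM to 9000 nM.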

Compound 3, half-maximal inhibitory concentration: > 10000 nM
Compound 3: no number, only a limit; the forecaster's own chance of this, stated with the estimate: 5%; middle value at least 2.5-fold (0.39 log units) away from the limit.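

Compound 1 and compound 2 suggested that this position tolerates quite different groups, but the new result shows that it does not accept every group equally. In this assay, 4-bromophenyl in place of 2-fluorophenyl on the saturated chain carbon gives an at least 2.3-fold higher number from compound 2 to compound 3 (0.36 log units; beyond the scatter), and 4-bromophenyl in place of 2-methylprop-1-en-1-yl gives an at least 2.6-fold higher number from compound 1 to compound 3 (0.42 log units; beyond the scatter). The result for compound 3 is a limit of the assay and not a number, so the full size of both steps stays unknown: the limit of > 10000 nM in this assay, at which 1 of the 3 values shown sits.

The change from 2-fluorophenyl to 4-bromophenyl alters both the halogen and its place on the ring, and the compounds shown cannot separate these two changes, which 4-fluorophenyl or 2-bromophenyl could do. From the compounds shown here alone, how an amine or a carboxylic acid on this chain would behave also remains open.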